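The compounds below may be only part of what the source reports. "The series", "measured", "known", "first", "only" and "open" are said of these compounds alone.

Compound 2 `O=C(NC(=S)N1CCc2c(OCCCCCOc3ccc(Cl)cc3)cccc21)c1ccc(Cl)cc1`: in an ADME assay on Huh-7 cells (Homo sapiens) for cytotoxicity (on this read-out higher numbers stand for lower toxicity in this test and lower numbers for higher toxicity in this test), compound 2 gives 21700 nM.
Compound 1 `O=C(NC(=S)N1CCc2c(OCCCCCOc3ccc(Cl)cc3)cccc21)Oc1ccccc1`: in this assay compound 1 reaches only an assay limit, > 50000 nM.

Compound 2 therefore holds the only number shown. Compound 1 sits at a limit (the limit of > 50000 nM in this assay, at which 1 of the 2 values shown sits). Going by the values given here, the one measured step, an at least 2.3-fold lower number from compound 1 to compound 2 (0.36 log units; beyond the scatter), came with 4-chlorophenyl in place of phenoxy on a carbonyl carbon. Compound 3 `COc1ccc(C(=O)NC(=S)N2CCc3c(OCCCCCOc4ccc(Cl)cc4)cccc32)cc1` differs from compound 2 by methoxy in place of chloro on an aromatic carbon. Among the compounds with values here, no measured step touches that change, so no shift beyond the scatter is expected in this assay. Compound 3 is estimated at 30000 nM, with a range from 12000 nM to 60000 nM. The expected step is a 1.4-fold higher number from compound 2 to compound 3 (0.14 log units; within the scatter).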

Compound 3, half-maximal cytotoxic concentration: 34400 nM
Beside the measured number, compound 3's estimate is 1.1-fold (0.06 log units) below it, within the range that was stated.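

In this assay, methoxy in place of chloro on this aromatic carbon gave a 1.6-fold higher number from compound 2 to compound 3 (0.20 log units; within the scatter), so this exchange on the ring shows no shift beyond the scatter. Replacing phenoxy with 4-methoxyphenyl gave an at least 1.4-fold lower number from compound 1 to compound 3 (0.16 log units; that floor lies within the scatter), so unlike the change to 4-chlorophenyl, this change has a floor that does not clear the scatter. The true size of that step stays unknown, as compound 1 gives only a limit: the limit of > 50000 nM in this assay, at which 1 of the 3 values shown sits.

The compounds shown leave open whether an amine or a carboxylic acid on this aromatic carbon would move the number beyond the scatter.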